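From dimethylamino to 3-hydroxypyrrolidin-1-yl in compound 4

The source may hold more compounds than are shown below. What is called first, only, known or untested is meant among the compounds shown, and "the series" means these compounds.

In an ADME assay on Caco-2 cells (Homo sapiens) for permeability (a lower number here means that the compound crosses the layer more slowly, a higher number that the compound crosses the layer faster), compound 2 `CN(C)Cc1ccccc1-c1ccc(N2CCc3c(C(F)(F)F)nn(-c4ccc5onc(N)c5c4)c3C2=O)c(F)c1` gives 8.9 10^-6 cm/s, and compound 3 `CN(C)Cc1ccccc1-c1ccc(N2CCc3c(C(F)(F)F)nn(-c4ccc5onc(N)c5c4)c3C2=O)cc1` gives 4.7 10^-6 cm/s. For the measured compounds named here, these two values lie within the scatter of each other, so compound 2 stands level with its only measured neighbour. For compound 1 `Nc1noc2ccc(-n3nc(C(F)(F)F)c4c3C(=O)N(c3ccc(-c5ccccc5CN5CCCC5)cc3F)CC4)cc12` the entry reads "not determined" (no result reported), so it offers no number for comparison.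

Compound 4 `Nc1noc2ccc(-n3nc(C(F)(F)F)c4c3C(=O)N(c3ccc(-c5ccccc5CN5CC[C@@H](O)C5)cc3F)CC4)cc12` carries 3-hydroxypyrrolidin-1-yl in place of dimethylamino on a saturated chain carbon bound to an aromatic carbon. Going by the values given here, the one measured step, a 1.9-fold lower number from compound 2 to compound 3 (0.28 log units; within the scatter), is hydrogen in place of fluoro on an aromatic carbon and stays within the scatter. Among the compounds with values here, no measured step therefore covers this swap, and the forecast is uncertain. Going by the structural change alone, including the hydrogen-bond donor that enters, a modestly lower number is expected in this assay. The estimated change is a 2.0-fold lower number from compound 2 to compound 4 (0.30 log units; within the scatter), which may not clear the scatter. For compound 4 the expected value is 4.5 10^-6 cm/s, with an estimated range of 1.5 10^-6 cm/s to 10 10^-6 cm/s.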

Compound 4, apparent permeability: 13 10^-6 cm/s
Compound 4: the middle estimate sits 2.9-fold (0.46 log units) below what was measured, outside the stated range (above it).
By their numbers in this assay, from the lowest: compounds 3, 2 and 4 (each within the scatter of the next, the first and the last beyond it).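

In this assay, putting 3-hydroxypyrrolidin-1-yl in place of dimethylamino on this saturated chain carbon gives a 1.5-fold higher number from compound 2 to compound 4 (0.16 log units; within the scatter), so compound 2 and compound 4 stand level. For the compounds shown here, this is the first measured step at this position, and it shows that a larger group, bringing a five-membered ring, a hydrogen-bond donor and a defined stereocentre, can enter here without moving the number beyond the scatter. Nothing measured here gives a reason for this result.

As far as these compounds go, for compound 1, which carries a pyrrolidine ring without the hydroxyl, the entry reads "not determined" (no result reported), so the steps to it cannot be read and the contribution of the hydroxyl on its own stays unknown. Also open, from the compounds shown here alone, is whether a morpholine ring or a piperazine ring on the same carbon would stand level with compound 2 as well.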